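The compounds below may be only part of what the source reports. "The series", "measured", "known", "first", "only" and "open" are said of these compounds alone.

Compound 2, whose structure is `Fc1cccc(-c2nc(Nc3ccc(Cl)cc3)c3cc(F)ccc3n2)c1`, stands at the edge of what a functional assay on MCF7 cells (Homo sapiens) for cytotoxicity, read by MTT assay, with a stated time of 48 h (a higher number here means a weaker inhibitor, a lower number a stronger inhibitor), can report: in this assay compound 2 gives only a limit, > 50000 nM. Its two measured neighbours do the same. Compound 1, with the structure `Fc1ccc(Nc2nc(-c3cccc(F)c3)nc3ccc(F)cc23)cc1`, gives only a limit in this assay, > 50000 nM. Compound 3, with the structure `Nc1cccc(Nc2nc(-c3cccc(F)c3)nc3ccc(F)cc23)c1`, also gives only a limit in this assay, > 50000 nM. Because of the limit of > 50000 nM in this assay, at which 3 of the 3 values shown sit, none of the three measured steps can be read in size: a step that the two limits leave unreadable from compound 1 to compound 2, a step that the two limits leave unreadable from compound 1 to compound 3 and a step that the two limits leave unreadable from compound 2 to compound 3 all remain unreadable.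

The unmeasured compound 4, with the structure `Cc1ccccc1Nc1nc(-c2cccc(F)c2)nc2ccc(F)cc12`, differs from compound 2 by 2-methylphenyl in place of 4-chlorophenyl on a nitrogen on an aromatic ring. Going by the values given here, the two measured steps that also exchange the group on that nitrogen, a step that the two limits leave unreadable from compound 1 to compound 3 and a step that the two limits leave unreadable from compound 2 to compound 3, bear on this change, but both are of unreadable size, so they give no direction beyond the fact that every compound so far sits at the limit. No step beyond the scatter is therefore expected in this assay.

Compound 4 is estimated to sit at about 100000 nM, in a range from 30000 nM to 400000 nM. The step that the limit leaves unreadable from compound 2 to compound 4 is expected to stay within the scatter, and the most likely outcome is that compound 4 too is reported only as a limit.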

Compound 4, half-maximal inhibitory concentration: > 50000 nM
Compound 4: no number, only a limit; the forecaster's own chance of this, stated with the estimate: 85%; the middle value does not contradict the limit.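

In this assay compound 4 gives only a limit, > 50000 nM. Its steps from compound 1, compound 2 and compound 3 therefore cannot be read in size: the limit of > 50000 nM in this assay, at which 4 of the 4 values shown sit.

The compounds shown leave open whether exchanging the group on the nitrogen changes the result in this assay at all, as none of compound 1, compound 2, compound 3 or compound 4 gives a number.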